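Phenyl in place of isopropyl on the amide-type nitrogen

The compounds below may be only part of what the source reports. "The series", "measured", "known", "first", "only" and "open" are said of these compounds alone.

Measured in a functional assay on A549 cells (Homo sapiens) for antiproliferative activity, read by MTT assay, with a stated time of 72 h; on this read-out lower numbers stand for stronger inhibition and higher numbers for weaker inhibition:
- compound 1 `O=C1COc2ccc(-c3cccc(NS(=O)(=O)c4ccc(F)cc4)c3)cc2N1`: 32100 nM
- compound 2 `COc1ncc(-c2ccc3c(c2)N(c2ccccc2)C(=O)CO3)cc1NS(=O)(=O)c1ccc(F)cc1`: 3490 nM
- compound 3 `CC(C)N1C(=O)COc2ccc(-c3cccc(NS(=O)(=O)c4ccc(F)cc4)c3)cc21`: 29400 nM

Compound 3 gives 29400 nM, level within the scatter with compound 1 and clearly higher than the number for compound 2.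

Compound 4 `O=C1COc2ccc(-c3cccc(NS(=O)(=O)c4ccc(F)cc4)c3)cc2N1c1ccccc1` puts phenyl in place of isopropyl on an amide-type nitrogen in a ring.

Within the data shown here, the one measured step at this nitrogen is a 1.1-fold lower number from compound 1 to compound 3 (0.04 log units; within the scatter), with isopropyl in place of hydrogen, so replacing hydrogen with isopropyl there made no visible difference. It says nothing directly about phenyl. Among the measured compounds shown here, compound 2 is the only measured compound carrying phenyl on that nitrogen, and it gives 3490 nM, but no measured step isolates that group. In this assay a modest fall in the number is therefore expected, smaller than the gap to compound 2. The expected change is a 2.0-fold lower number from compound 3 to compound 4 (0.29 log units; within the scatter). For compound 4 the estimated value is 15000 nM, with an expected range from 5000 nM to 40000 nM.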

Compound 4, half-maximal inhibitory concentration: > 40000 nM
Compound 4: only a limit was reported; the forecaster's own chance of this, stated with the estimate: 10%; middle value at least 2.6-fold (0.42 log units) away from the limit.
By their numbers in this assay, from the lowest: compound 2; then compounds 3 and 1 (each within the scatter of the next). At a limit, above all of these: compound 4.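

In this assay compound 4 is reported only as a limit, not as a number: the limit of > 40000 nM in this assay, at which 1 of the 4 values shown sits.

Read as floors, the steps are an at least 1.3-fold higher number from compound 3 to compound 4 (0.13 log units; that floor lies within the scatter) and an at least 1.2-fold higher number from compound 1 to compound 4 (0.09 log units; that floor lies within the scatter); each floor lies within the scatter, and the true size of either step remains unknown. Even so, phenyl on the amide-type nitrogen brings no fall in the number on this core, which the earlier step from hydrogen to isopropyl could not show for an aromatic ring.

Among these compounds, no step in one place links compound 2 to the other compounds, so its lower value cannot be assigned to any single group. Going by these compounds, whether a longer chain, an amine or a carboxylic acid on that nitrogen would give a number inside the measurable range stays open.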